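A few compounds are considered here, and "the series" means these few. Any claim that something is new, unique, unknown or untested is made for them only; others in the source may bear on it.

In an ADME assay on a cell-free system (plasma, Mus musculus) for metabolic stability, tested at 1 uM (a lower number here means that the compound disappears faster, a higher number that the compound lasts longer), three compounds have been measured so far, and none of them gives a plain number. Compound 1 (`C=CC(=O)NCC1CCN(S(=O)(=O)c2ccc(NC(=O)OCc3ccccc3)cc2)CC1`) gives > 6 h, which is a limit of the assay. Compound 2 (`C=CC(=O)N[C@H]1CCN(S(=O)(=O)c2ccc(NC(=O)OCc3ccccc3)cc2)C1`) gives > 6 h, again a limit. Compound 3 (`C=CC(=O)NC1CCN(S(=O)(=O)c2ccc(C(=O)NCCCc3ccccc3)cc2)CC1`) gives > 6 h, also a limit, so its standing in this assay is known no more closely than that of the other two. Compound 4 (`C=CC(=O)NC1CCN(S(=O)(=O)c2ccc(C(=O)NC3CCCc4ccccc43)cc2)CC1`) differs from compound 3 on an amide-type nitrogen, where 1,2,3,4-tetrahydronaphthalen-1-yl takes the place of 3-phenylpropyl: 1,2,3,4-tetrahydronaphthalen-1-yl in place of 3-phenylpropyl on an amide-type nitrogen. Among the measured compounds shown here, no measured pair shows what a change at this place does. The expectation therefore rests on (the limit of > 6 h in this assay, at which 3 of the 3 values shown sit), and no shift beyond the usual scatter is expected in either direction. The expected step that the limit leaves unreadable from compound 3 to compound 4 is accordingly small. Compound 4 is estimated at 8 h, with an expected range of 4 h to 20 h, and it may well be reported only as a limit.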

Compound 4, half-life: > 6 h
Compound 4: a limit, no number; the forecaster's own chance of this, stated with the estimate: 80%; the middle value does not contradict the limit.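

In this assay, among the compounds shown here, compound 3 and compound 4 both stand only as limits, so no step between them can be read. The compounds shown leave open how long any of them actually lasts, and whether 1,2,3,4-tetrahydronaphthalen-1-yl in place of 3-phenylpropyl alters the half-life at all.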